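Replacing Methoxy with Amino on the Aromatic Ring

A few compounds are considered here, and "the series" means these few. Any claim that something is new, unique, unknown or untested is made for them only; others in the source may bear on it.

In a functional assay on KB cells (Homo sapiens) for antiproliferative activity, read by sulforhodamine B assay, with a stated time of 48 h (a lower number here means a stronger inhibitor of growth, a higher number a weaker inhibitor of growth), compound 1 `COc1ccc(Nc2nc(NC3CCCC3)c3ccccc3n2)cc1` gives 11100 nM and compound 2 `COc1ccc(N(C)c2nc(NC3CCCC3)c3ccccc3n2)cc1` gives 11700 nM so the two stand level within the scatter. Compound 3 `Nc1ccc(Nc2nc(NC3CCCC3)c3ccccc3n2)cc1` differs from compound 1 by amino in place of methoxy on an aromatic carbon with amino in place of methoxy on an aromatic carbon, para to a large group. Going by the values given here, the one measured step of a 1.1-fold higher number from compound 1 to compound 2 (0.02 log units; within the scatter) puts methyl in place of hydrogen on a nitrogen and leaves the methoxy untouched, so it offers little guidance here. The expected result is a 1.1-fold lower number from compound 1 to compound 3 (0.05 log units; within the scatter) with no shift beyond the scatter in either direction. Compound 3 is estimated at 10000 nM with a range from 3000 nM to 30000 nM as a wide allowance.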

Compound 3, concentration for 50% growth inhibition: 17400 nM
Estimate against measurement, compound 3: 1.7-fold (0.24 log units) below, within the range that was stated.
By their numbers in this assay, from the lowest: compounds 1, 2 and 3 (each within the scatter of the next).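

In this assay, going from 4-methoxyphenyl to 4-aminophenyl gives a 1.6-fold higher number from compound 1 to compound 3 (0.20 log units; within the scatter), so amino can stand in place of methoxy on this aromatic carbon, para to a large group, without a change that can be told from the scatter. The earlier step altered a nitrogen and left this methoxy untouched. No measurement given here accounts for the result. From the compounds shown here alone, whether a carboxylic acid or a longer chain at this position would move the number beyond the scatter remains open.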